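A few compounds are considered here, and "the series" means these few. Any claim that something is new, unique, unknown or untested is made for them only; others in the source may bear on it.

Of the compounds shown here, three built on one shared core have been tested in an ADME assay on BJ cells (Homo sapiens), read by MTT assay, with a stated time of 72 h; a lower number here means a stronger inhibitor, a higher number a weaker inhibitor. Compound 1 `COc1ncnc2c1c(-c1ccccc1)cn2[C@@H]1O[C@H](CO)[C@@H](O)[C@H]1O` reports > 100000 nM, which is a limit of the assay and not a number. Compound 2 `CSc1ncnc2c1c(-c1ccoc1)cn2[C@@H]1O[C@H](CO)[C@@H](O)[C@H]1O` gives 98800 nM, and compound 3 `CNc1ncnc2c1c(-c1ccco1)cn2[C@@H]1O[C@H](CO)[C@@H](O)[C@H]1O` gives 5040 nM. Compound 3 therefore holds the lower of the two true numbers, and its gap to compound 2 lies well beyond the usual scatter.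

Compound 4 `CNc1ncnc2c1c(-c1ccsc1)cn2[C@@H]1O[C@H](CO)[C@@H](O)[C@H]1O` has not been measured yet. It differs from compound 3 in one place, with thiophen-3-yl in place of furan-2-yl on an aromatic carbon. Both groups are five-membered aromatic rings with 1 hetero atom, so this is a swap between close relatives.

Among the measured compounds shown here, no two measured compounds differ in only one place, so the data give no direct measure of such a swap. For the measured compounds named here, compound 3, at 5040 nM, is the lowest number so far, and compound 2, at 98800 nM, shows that this series can also sit much higher. A small move toward a higher number is therefore expected in this assay, perhaps no larger than the scatter. The expected change is a 1.8-fold higher number from compound 3 to compound 4 (0.25 log units; within the scatter). For compound 4 the estimated value is 9000 nM, with an expected range from 2500 nM to 40000 nM.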

Compound 4, half-maximal inhibitory concentration: > 100000 nM
Compound 4 ended at the assay's limit; the forecaster's own chance of this, stated with the estimate: 10%; middle value at least 11-fold (1.04 log units) away from the limit.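

Among the compounds shown here, this is the first change made at one place alone, and it shows that this aromatic carbon is not a silent position in this assay: replacing furan-2-yl with thiophen-3-yl brings an at least 19-fold higher number from compound 3 to compound 4 (1.29 log units; beyond the scatter) in a single swap. Both groups are five-membered aromatic rings with 1 hetero atom, and they match in heavy atoms, hydrogen-bond donors and hydrogen-bond acceptors, so these counts alone do not separate two groups that lie far apart here. Compound 4 sits at a limit of the assay and not at a number, so the step gives only a lower bound on the true change, since the read-out stops at this ceiling: the limit of > 100000 nM in this assay, at which 2 of the 4 values shown sit.

The swap changes both the ring's hetero atom, from oxygen to sulfur, and the ring's point of attachment, so the compounds shown cannot say which of the two matters; thiophen-2-yl on the core of compound 3 would separate them. Also open, from the compounds shown here alone, is how this position responds to a group that is not an aromatic ring, such as a primary amine or a carboxylic acid.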